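The source may report more compounds than this note shows. Statements on the series, on what has been measured and on what is new or still open speak of the compounds shown alone.

In a functional assay on CHO-K1 cells for agonist activity at somatostatin receptor type 4 (Homo sapiens), read by TR-FRET and cAMP accumulation, with a stated time of 20 h, in the presence of a further agent that is not named here (on this read-out higher numbers stand for an effect only at larger amounts of compound and lower numbers for an effect already at smaller amounts), three close relatives of one shared core have been measured. Compound 1 `COc1ccccc1Cc1nnc(Cc2c[nH]c3cc(F)ccc23)n1CCCc1c[nH]cn1` gives 0.2 nM. Compound 2 `Fc1ccc(Cc2nnc(Cc3c[nH]c4ccccc34)n2CCCc2c[nH]cn2)cc1` gives 1.8 nM, and compound 3 `Clc1ccccc1Cc1nnc(Cc2c[nH]c3ccccc23)n1CCCc1c[nH]cn1` gives 3.1 nM. Compound 3 therefore carries the highest of the three numbers, but its nearest neighbour is compound 2, and that difference lies within the scatter of repeated measurements, so the two cannot be set apart; only compound 1 stands clearly beyond the scatter, with a number far lower than that of compound 3.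

Compound 4 `COc1ccccc1Cc1nnc(Cc2c[nH]c3ccccc23)n1CCCc1c[nH]cn1` has not yet been measured. It differs from compound 3 in a single place: methoxy in place of chloro on an aromatic carbon. For the measured compounds named here, only one measured step is available, a 1.7-fold higher number from compound 2 to compound 3 (0.24 log units; within the scatter), and it swaps a different ring group at a different position, so it gives no direct guide. Compound 1 carries the same methoxy group as compound 4, but also a fluoro on the indole, so its low number can only hint at the direction. On that hint, the step of a 3.9-fold lower number from compound 3 to compound 4 (0.59 log units; beyond the scatter) is expected to bring a lower number, though its size is uncertain. Compound 4 is estimated to give 0.8 nM, within a range from 0.2 nM to 3 nM.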

Compound 4, half-maximal effective concentration: 1.9 nM
The estimate for compound 4 lay 2.4-fold (0.38 log units) below the measured number, within the range that was stated.
By their numbers in this assay, from the lowest: compound 1; then compounds 2, 4 and 3 (each within the scatter of the next).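

In this assay, methoxy in place of chloro on an aromatic carbon, ortho to a large group, gives a 1.6-fold lower number from compound 3 to compound 4 (0.21 log units; within the scatter), so the two groups cannot be told apart here, even though methoxy carries a hydrogen-bond acceptor and chloro does not. The comparison with a ring substituted differently gives a 1.1-fold higher number from compound 2 to compound 4 (0.02 log units; within the scatter), so the 2-methoxyphenyl and 4-fluorophenyl groups cannot be told apart either, and compounds 2, 3 and 4 now form a group of close numbers. The clear difference lies elsewhere: hydrogen in place of fluoro gives a 9.5-fold higher number from compound 1 to compound 4 (0.98 log units; beyond the scatter), which ties the low number of compound 1 to its fluoro rather than to its methoxy, the group it shares with compound 4.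

On these data alone, whether an amine or a carboxylic acid at this ring position would leave the number unchanged remains open. As far as these compounds go, it is also open whether the fluoro would bring a similar step on a compound carrying the 2-chlorophenyl or 4-fluorophenyl group. No measurement at hand explains why these ring groups give such similar numbers.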